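A few compounds are considered here, and "the series" means these few. Any claim that something is new, unique, unknown or untested is made for them only; others in the source may bear on it.

The three measured compounds share a core carrying a trifluoroanilide or related group and a pyrrolidinone. Compound 1 `C[C@H]1Cn2ncc(N3CC(c4ccccc4)CC3=O)c2CN1S(=O)(=O)Nc1cc(F)c(F)c(F)c1` was tested in a toxicity assay on HepG2 2.2.15 cells (Homo sapiens) for cytotoxicity, read by CellTiter-Glo (a higher number here means that more compound is tolerated, a lower number that less compound is tolerated), and gave only a limit of the assay, > 2000 nM. Compound 2 `CC1CCn2ncc(N3CC(c4ccccc4)CC3=O)c2CN1C(=O)Nc1cc(F)c(F)c(F)c1` likewise gave only a limit in this assay, > 2000 nM. Within the data shown here, compound 3 `O=C1CC(Oc2ncc(F)cn2)CN1c1cnn2c1CN(C(=O)Nc1cc(F)c(F)c(F)c1)C(C1CC1)C2` is the one member of the set with a numerical half-maximal cytotoxic concentration: in this assay compound 3 gives 96200 nM, the only number in the set, while the other two values sit at the limit of > 2000 nM in this assay, at which 2 of the 3 values shown sit. No comparison between two measured compounds can be drawn from these three results, since two of them are limits.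

Compound 4 `Cc1nc(C2CC(=O)N(c3cnn4c3CN(C(=O)Nc3cc(F)c(F)c(F)c3)C(C3CC3)C4)C2)no1` is compared with compound 3. The difference is computed from the two structures as 5-methyl-1,2,4-oxadiazol-3-yl in place of (5-fluoropyrimidin-2-yl)oxy on a saturated ring carbon. Among the measured compounds shown here, both the leaving and the entering groups are small aromatic heterocycles on the same saturated ring carbon, and no measured step of this kind exists in the set. Compound 4 is therefore expected to stay close to compound 3 in this assay, with a step from compound 3 to compound 4 of a 1.2-fold lower number from compound 3 to compound 4 (0.08 log units; within the scatter), which is within the scatter. The estimate for compound 4 in this assay is 80000 nM, with a range from 30000 nM to 200000 nM.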

Compound 4, half-maximal cytotoxic concentration: > 200000 nM
Compound 4: only a limit was reported; the forecaster's own chance of this, stated with the estimate: 20%; at least 2.5-fold (0.39 log units) between middle value and limit.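

In this assay, among these compounds, the 5-methyl-1,2,4-oxadiazol-3-yl group in place of (5-fluoropyrimidin-2-yl)oxy on this saturated ring carbon gives an at least 2.0-fold higher number from compound 3 to compound 4 (0.31 log units; beyond the scatter), the first step in the set that can be read, and it shows that a change at this position alone can move the tolerated concentration beyond the scatter. Compound 4 gives > 200000 nM, which is a limit of the assay and not a number. The step therefore fixes only the direction and a smallest size, and how far compound 4 truly lies from compound 3 stays unknown, as this result sits at the top of the range shown: the limit of > 200000 nM in this assay, at which 1 of the 4 values shown sits.

The steps involving compounds 1 and 2 cannot be read, as those compounds also give only limits and differ from compound 3 in more than one place. With a single exchange at this carbon, the compounds shown leave open whether the result follows from the oxadiazole ring itself or from the loss of the oxygen link, and how a simple amine or a carboxylic acid on the same carbon would behave in this assay.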